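Closing the Loop from Thiourea Back to Urea

The compounds below may be only part of what the source reports. "The series", "measured", "known", "first", "only" and "open" are said of these compounds alone.

Measured so far:
compound 1 `O=C(NCCNS(=O)(=O)c1ccc(-c2ccccc2OCc2ccccc2)s1)Nc1cc(Cl)cc(Cl)c1` — 11700 nM
compound 2 `O=[N+]([O-])c1ccc(NC(=S)NCCNS(=O)(=O)c2ccc(-c3ccccc3OCc3ccccc3)s2)cc1` — > 50000 nM, which is a limit of the assay and not a number

Both compounds were tested in a functional assay on HL-60 cells (Homo sapiens) for inhibition, read by CCK-8 assay, with a stated time of 48 h; a lower number here means a stronger inhibitor, a higher number a weaker inhibitor. Compound 2 therefore stands only at the edge of what this assay can report, with no exact value, as marked by the limit of > 50000 nM in this assay, at which 1 of the 2 values shown sits. Compound 3 `COc1cccc(NC(=O)NCCNS(=O)(=O)c2ccc(-c3ccccc3OCc3ccccc3)s2)c1` has not yet been measured; it differs from compound 2 in one place: a group of 11 heavy atoms (8 carbon, 1 nitrogen, 2 oxygen; one six-membered aromatic ring of carbon only) in place of a group of 12 heavy atoms (7 carbon, 2 nitrogen, 2 oxygen, 1 sulfur; one six-membered aromatic ring of carbon only), on an amine nitrogen.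

Among the compounds with values here, one measured step bears on this change. Going an at least 4.2-fold higher number from compound 1 to compound 2 (0.63 log units; beyond the scatter), the move from a chlorinated phenyl urea to a nitrophenyl thiourea raised the number to the limit. Compound 3 reverses part of that move, returning to a urea while carrying a methoxyphenyl group, so the expectation is a step back downward, an at least 3.3-fold lower number from compound 2 to compound 3 (0.52 log units; beyond the scatter), toward the region where compound 1 sits. Compound 3 is therefore estimated at 15000 nM in this assay, with a likely range from 5000 nM to 50000 nM, and some chance that only a limit is again reported.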

Compound 3, half-maximal inhibitory concentration: 1700 nM
Beside the measured number, compound 3's estimate is 8.8-fold (0.95 log units) above it, and the stated range ends above it.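

In this assay, keeping the urea and changing only the aromatic group shows that this group alone shifts the result: 3-methoxyphenyl in place of 3,5-dichlorophenyl gives a 6.9-fold lower number from compound 1 to compound 3 (0.84 log units; beyond the scatter). The gap to the thiourea is larger, an at least 29-fold lower number from compound 2 to compound 3 (1.46 log units; beyond the scatter), but that change replaces the thiourea and the nitrophenyl group together, so the share of each cannot be told from these compounds. The value of compound 2 is a limit of the assay and not a number: the limit of > 50000 nM in this assay, at which 1 of the 3 values shown sits.

The compounds shown leave open how a thiourea carrying the same 3-methoxyphenyl group would compare with compound 3, a pair that would separate the sulfur-for-oxygen change from the change of aromatic group. Also open, as far as these compounds go, is whether the methoxy group itself matters, which a urea carrying a plain phenyl or a pyridine ring in its place could begin to answer.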